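Cyano to 2-phenylethenyl on the shared core

The source may report more compounds than this note shows. Statements on the series, on what has been measured and on what is new or still open speak of the compounds shown alone.

Compound 1 `C=C[C@@](C)(/C=C/c1ccc(O)cc1)CCC=O`: > 52000 nM (a limit)
Compound 2 `C=C[C@@](C)(/C=C/c1ccc(O)cc1)CCCO`: > 52000 nM (a limit)
Compound 3 `C=C[C@@](C)(/C=C/c1ccc(O)c(/C=C/C#N)c1)CCC=C(C)C`: > 52000 nM (a limit)

These values come from a functional assay on HepG2 cells (Homo sapiens) for cytotoxicity, with a stated time of 72 h (a lower number here means that less compound is needed, a higher number that more compound is needed for the effect), and none is a true number. Compound 3 reads > 52000 nM here, which is a limit. The whole record is the limit of > 52000 nM in this assay, at which 3 of the 3 values shown sit, and nothing finer. Compound 4 `C=C[C@@](C)(/C=C/c1ccc(O)c(/C=C/C=C/c2ccccc2)c1)CCC=C(C)C` carries 2-phenylethenyl in place of cyano on a double-bonded chain carbon bound to a double-bonded chain carbon. Among the measured compounds shown here, the only measured step is a step that the two limits leave unreadable from compound 1 to compound 2 and it involves a different change, so no measured step bears on this one. The expected change is therefore none beyond the scatter, and the estimated step is an at least 1.1-fold lower number from compound 3 to compound 4 (0.06 log units; that floor lies within the scatter) in this reading. For compound 4 the estimated value is 45000 nM with an expected range of 18000 nM to 52000 nM in this assay once measured.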

Compound 4, half-maximal effective concentration: > 52000 nM
Compound 4: a limit, no number; the forecaster's own chance of this, stated with the estimate: 65%; middle value at least 1.1-fold (0.06 log units) from the limit.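

Compound 3 and compound 4 both stop at a limit, so no step between them can be read: the limit of > 52000 nM in this assay, at which 4 of the 4 values shown sit.

Left open is where any of the four compounds would give a true number in this assay, and so how cyano and 2-phenylethenyl compare.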